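Swapping the para group on a biaryl naphthol

A few compounds are considered here, and "the series" means these few. Any claim that something is new, unique, unknown or untested is made for them only; others in the source may bear on it.

Three compounds share one core, a naphthol carrying a phenyl ring whose far end bears a single substituent. Compound 1 `COc1ccc(-c2ccc3c(O)cccc3c2)cc1` carries a methoxy there and in an assay for binding affinity to 17-beta-hydroxysteroid dehydrogenase type 1 (Homo sapiens), with a stated time of 20 min, tested at 1 uM (on this read-out higher numbers stand for more inhibition at the one concentration tested (going by the name of the read-out) and lower numbers for less inhibition), compound 1 gives 28%. Compound 2 `O=[N+]([O-])c1ccc(-c2ccc3c(O)cccc3c2)cc1` carries a nitro instead; in this assay compound 2 gives 15%. Compound 3 `N#Cc1ccc(-c2ccc3c(O)cccc3c2)cc1` carries a cyano, and in this assay compound 3 gives 16%. Compound 3 thus stands second highest of the three: against compound 2 the step of a number 1 percentage points higher from compound 2 to compound 3 (within the scatter) lies within the scatter, while against compound 1 the step of a number 12 percentage points lower from compound 1 to compound 3 (beyond the scatter) lies beyond it, as does a number 13 percentage points lower from compound 1 to compound 2 (beyond the scatter).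

Compound 4 `CC(=O)c1ccc(-c2ccc3c(O)cccc3c2)cc1` is the next member. The change from compound 3 is acetyl in place of cyano on an aromatic carbon; the cyano leaves and an acetyl enters at the same aromatic carbon, para to a large group. Within the data shown here, no measured step swaps cyano for acetyl, so the closest guides are the two steps from compound 1 and the flat step between compound 2 and compound 3, where two different one-acceptor groups gave numbers within the scatter of each other. A step of a number 2 percentage points higher from compound 3 to compound 4 (within the scatter) within the scatter is therefore expected. Compound 4 is estimated at 18%, with a range from 8% to 30%.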

Compound 4, a percentage reported as inhibition, at one concentration (the size of the read-out at that concentration, not a potency): 16%
Compound 4: the middle estimate sits 2 percentage points above what was measured, within the range that was stated.
By their numbers in this assay, from the lowest: compounds 2, 3 and 4 (each within the scatter of the next); then compound 1.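

Acetyl at this aromatic carbon shows that the flat result for the nitro and cyano groups extends to a third group with a different make-up: there is no change at the digits printed from compound 3 to compound 4 (within the scatter) in this assay and a number 1 percentage points higher from compound 2 to compound 4 (within the scatter) as well. Exchanging the 2 heavy atoms and triple bond of cyano for the 3 heavy atoms and double bond of acetyl therefore leaves no change that this read-out can distinguish, while the methoxy group remains apart, with a number 12 percentage points lower from compound 1 to compound 4 (beyond the scatter) as a further step beyond the scatter. Among these four compounds, methoxy alone gives a number separated from the rest, and nothing measured here accounts for that separation.

The compounds shown leave open whether the higher number of compound 1 at 28% would persist with an ethoxy or a hydroxyl group at this aromatic carbon, or whether an amine or a carboxylic acid would give a number nearer to that of compound 1 or compound 4. On these data alone, each number also comes from a single concentration, so how these compounds compare in potency remains unknown.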